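Swapping the Outer Ring for an Indole in Raji Cells

A few compounds are considered here, and "the series" means these few. Any claim that something is new, unique, unknown or untested is made for them only; others in the source may bear on it.

Compound 3 `CC(C)Oc1cccc(-c2ccc(C(=O)N(Cc3cccc(OCCCCCC(=O)O)c3)C(C)C)cc2)c1` carries a 3-isopropoxyphenyl group on its outer aromatic ring. In an ADME assay on Raji cells (Homo sapiens) for cytotoxicity, read by CellTiter-Glo and resazurin assay, with a stated time of 72 h (on this read-out lower numbers stand for an effect already at smaller amounts and higher numbers for an effect only at larger amounts of compound), compound 3 gives only a limit of the assay, > 26000 nM. Compound 1 `CC(C)N(Cc1cccc(OCCCCCC(=O)O)c1)C(=O)c1ccc(-c2cccc(N(C)C)c2)cc1` in this assay also gives only a limit, > 26000 nM. Compound 2 `CC(C)N(Cc1cccc(OCCCCCC(=O)O)c1)C(=O)c1ccc(-c2ccncc2)cc1` likewise gives only a limit, > 26000 nM. All three measured values thus sit at one place, (the limit of > 26000 nM in this assay, at which 3 of the 3 values shown sit), so none of the compounds shows a measurable effect within the tested range. Compound 4 `CC(C)N(Cc1cccc(OCCCCCC(=O)O)c1)C(=O)c1ccc(-c2ccc3[nH]ccc3c2)cc1` differs from compound 3 in a single place: 1H-indol-5-yl in place of 3-isopropoxyphenyl on an aromatic carbon. The steps already measured, a step that the two limits leave unreadable from compound 1 to compound 3, a step that the two limits leave unreadable from compound 2 to compound 3 and a step that the two limits leave unreadable from compound 1 to compound 2, each join two limits, so their size and direction stay hidden. There is therefore no measured evidence that changing this outer ring moves the read-out at all. Compound 4 is expected to behave like the others, with an estimated value of 40000 nM, ranging from 20000 nM to 100000 nM. The expected step from compound 3 is a step that the limit leaves unreadable from compound 3 to compound 4, most likely again reported only as a limit.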

Compound 4, half-maximal effective concentration: > 26000 nM
Compound 4: no number, only a limit (the forecaster's own chance of this, stated with the estimate: 80%); the middle value lies beyond the limit too.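

Compound 4 also gives only a limit, so the steps to it from compound 1, compound 2 and compound 3 cannot be read in size or direction: the limit of > 26000 nM in this assay, at which 4 of the 4 values shown sit. On these data alone, whether any of these four outer groups shifts the read-out in this assay at all stays open.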